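Hydroxy for Methyl at the Cytotoxicity Limit

A few compounds are considered here, and "the series" means these few. Any claim that something is new, unique, unknown or untested is made for them only; others in the source may bear on it.

Compound 1, `O=C1c2ccccc2NS(=O)(=O)N1COCCO`: > 200 ug/mL
Compound 2, `CCCOCN1c2ccccc2C(=O)NS1(=O)=O`: > 200 ug/mL

In a functional assay on CCRF-CEM cells (Homo sapiens) for cytotoxicity (on this read-out higher numbers stand for lower toxicity in this test and lower numbers for higher toxicity in this test), compound 1 gives only a limit of the test, > 200 ug/mL. Compound 2 likewise gives only a limit in this test, > 200 ug/mL. On the numbers shown, compound 2 therefore stands at the limit of > 200 ug/mL in this assay, at which 2 of the 2 values shown sit. Compound 3, `O=C1NS(=O)(=O)N(COCCO)c2ccccc21`, differs from compound 2 by hydroxy in place of methyl on a saturated chain carbon, two bonds along the chain from an oxygen on a saturated carbon. No step beyond the usual scatter is expected in this assay. Compound 3 is expected at 300 ug/mL, with a range of 150 ug/mL to 600 ug/mL, an expected step that the limit leaves unreadable from compound 2 to compound 3.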

Compound 3, half-maximal cytotoxic concentration: 15 ug/mL
Estimate against measurement, compound 3: 20-fold (1.30 log units) above, and the stated range ends above it.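

Swapping one atom at the far end of the chain is enough to change the outcome: in this assay, replacing methyl with hydroxy gives an at least 13-fold lower number from compound 2 to compound 3 (1.12 log units; beyond the scatter). Among these compounds, neither earlier compound showed any toxicity that could be read as a number, so this is the first sign that this position matters, with the lower number meaning higher toxicity in this test. The starting point is only a limit of the test: the limit of > 200 ug/mL in this assay, at which 2 of the 3 values shown sit.

As far as these compounds go, whether an amine or a carboxylic acid at this chain end would act like hydroxy remains open. So does the effect of a longer chain ending in hydroxy.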